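Replacing a Benzyl Ether with a Benzotriazolyl Amine

The compounds below may be only part of what the source reports. "The series", "measured", "known", "first", "only" and "open" are said of these compounds alone.

Compound 1 `CC(C)(C)[Si](CCc1c(OCc2c(Cl)cccc2Cl)nc2ccc(Cl)cc2c1-c1ccccc1Cl)(c1ccccc1)c1ccccc1`: > 1020000 nM
Compound 2 `OCCc1c(OCc2c(F)cccc2F)nc2ccc(Cl)cc2c1-c1ccccc1Cl`: 109000 nM

In an ADME assay on HepG2 2.2.15 cells (Homo sapiens) for cytotoxicity (a lower number here means that less compound is tolerated, a higher number that more compound is tolerated), compound 1 reaches only > 1020000 nM, which is a limit of the assay and not a number (the limit of > 1020000 nM in this assay, at which 1 of the 2 values shown sits). Compound 2 gives 109000 nM in this assay, the only number shown, so it stands alone without a measured step to compare against. Compound 3 `OCCc1c(Nn2nnc3ccccc32)nc2ccc(Cl)cc2c1-c1ccccc1Cl` differs from compound 2 by a group of 10 heavy atoms (6 carbon, 4 nitrogen; one five-membered aromatic ring with 3 hetero atoms, one six-membered aromatic ring of carbon only) in place of a group of 10 heavy atoms (7 carbon, 1 oxygen, 2 fluorine; one six-membered aromatic ring of carbon only), on an aromatic carbon. Among the measured compounds shown here, with no measured step to lean on, the expected change in this assay is none beyond the scatter, as a 1.1-fold lower number from compound 2 to compound 3 (0.04 log units; within the scatter). Compound 3 is therefore estimated at 100000 nM, ranging from 30000 nM to 400000 nM.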

Compound 3, half-maximal cytotoxic concentration: 82400 nM
The estimate for compound 3 lay 1.2-fold (0.08 log units) above the measured number; the range from low to high includes it.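

On the aromatic carbon next to the ring nitrogen, the (2,6-difluorobenzyl)oxy group gives way to the benzotriazolyl amine, and this assay shows a 1.3-fold lower number from compound 2 to compound 3 (0.12 log units; within the scatter). This position thus carries two quite different groups of equal heavy-atom count, the entering one with a hydrogen-bond donor, without a step beyond the scatter. No measured property among the compounds shown bears on this step.

Open, on these data alone, is whether a smaller group at this position, such as a plain amine or a methoxy group, would read the same. Also open, as far as these compounds go, is how a carboxylic acid in place of the 2-hydroxyethyl group would read.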